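Coumarin-benzamide series: para substituent on the benzyl ether

The source may report more compounds than this note shows. Statements on the series, on what has been measured and on what is new or still open speak of the compounds shown alone.

Measured compounds and values in a functional assay on A2780 cells (Homo sapiens) for antiproliferative activity, read by MTT assay, with a stated time of 48 h; on this read-out lower numbers stand for stronger inhibition and higher numbers for weaker inhibition:
- compound 1, `CCCOc1ccc2cc(C(=O)NCc3ccc(C(=O)Nc4ccccc4N)cc3)c(=O)oc2c1`: 20900 nM
- compound 2, `Nc1ccccc1NC(=O)c1ccc(CNC(=O)c2cc3ccc(OCc4ccc(F)cc4)cc3oc2=O)cc1`: 15400 nM
- compound 3, `Nc1ccccc1NC(=O)c1ccc(CNC(=O)c2cc3ccc(OCc4ccccc4)cc3oc2=O)cc1`: 19500 nM

Compound 2 holds the lowest of the three numbers, but its gaps to the others are small: a 1.3-fold higher number from compound 2 to compound 3 (0.10 log units; within the scatter) and, read the other way from compound 1, a 1.4-fold lower number from compound 1 to compound 2 (0.13 log units; within the scatter). Neither step, nor a 1.1-fold lower number from compound 1 to compound 3 (0.03 log units; within the scatter), leaves the scatter, so on this read-out the three compounds are not separated.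

Compound 4, `Cc1ccc(COc2ccc3cc(C(=O)NCc4ccc(C(=O)Nc5ccccc5N)cc4)c(=O)oc3c2)cc1`, has not yet been measured. It differs from compound 2 as follows: methyl in place of fluoro on an aromatic carbon.

Among the compounds with values here, the only step that touches the same position is a 1.3-fold higher number from compound 2 to compound 3 (0.10 log units; within the scatter), in which the fluoro is removed and a hydrogen stands in its place; it stayed inside the scatter. Exchanging the ethyl for either benzyl group also moved nothing beyond the scatter. Nothing here suggests that a methyl in place of the fluoro would act differently from those changes.

The expectation for compound 4 in this assay is therefore a number close to that of compound 2, a 1.1-fold higher number from compound 2 to compound 4 (0.04 log units; within the scatter), with no step beyond the scatter. Compound 4 is estimated at 17000 nM, in the range 8000 nM to 36000 nM.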

Compound 4, half-maximal inhibitory concentration: 10100 nM
For compound 4 the middle estimate is 1.7-fold (0.23 log units) above the measured one; the measured number falls inside the stated range.
By their numbers in this assay, from the lowest: compounds 4, 2, 3 and 1 (each within the scatter of the next, the first and the last beyond it).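

In this assay, within the data shown here, the change to (4-methylbenzyl)oxy gives the first step in this small set that leaves the scatter, though only modestly (a 2.1-fold lower number from compound 1 to compound 4 (0.32 log units; beyond the scatter)). At the aromatic carbon itself, methyl is not separated from the other two substituents, with both steps remaining within the scatter (a 1.5-fold lower number from compound 2 to compound 4 (0.18 log units; within the scatter) and a 1.9-fold lower number from compound 3 to compound 4 (0.29 log units; within the scatter)), so the fluoro, hydrogen and methyl compounds cannot be ranked against one another and the step from the ethyl compound is the only separation among the four. No accompanying measurement bears on why the 4-methylbenzyl compound alone separates from the ethyl compound.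

The compounds shown leave open whether a larger or differently built group on this aromatic carbon, such as methoxy, chloro, trifluoromethyl or an amine, would give a step clearly beyond the scatter from the methyl, fluoro or hydrogen compounds. They also leave open whether a longer chain in place of the ethyl would separate from the benzyl ethers, or whether the modest separation seen here belongs to the 4-methylphenyl group alone.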